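The source may hold more compounds than are shown below. What is called first, only, known or untested is meant among the compounds shown, and "the series" means these compounds.

Working notes on the series. In a functional assay on HL-60 cells (Homo sapiens) for cytotoxicity, read by WST assay, with a stated time of 48 h (a lower number here means a stronger inhibitor, a higher number a weaker inhibitor), compound 1 (`O=[N+]([O-])c1cccc(/C=C/C[C@H]2C[C@@H]([C@@H](O)c3ccccc3)CO[C@@H]2c2ccccc2)c1`) gives 6350 nM, compound 2 (`O[C@@H](c1ccccc1)[C@H]1CO[C@H](c2ccccc2)[C@@H](C/C=C/C2CCCC2)C1`) gives 9060 nM, and compound 3 (`COc1ccccc1/C=C/C[C@H]1C[C@@H]([C@@H](O)c2ccccc2)CO[C@@H]1c1ccccc1`) gives 10100 nM. These three differ only in the group on a double-bonded chain carbon bound to a double-bonded chain carbon. Compound 3 cannot be separated from the other two, with a 1.1-fold higher number from compound 2 to compound 3 (0.05 log units; within the scatter) and a 1.6-fold higher number from compound 1 to compound 3 (0.20 log units; within the scatter).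

The next structure is compound 4 (`O[C@@H](c1ccccc1)[C@H]1CO[C@H](c2ccccc2)[C@@H](C/C=C/c2ccc(F)cc2)C1`), which carries 4-fluorophenyl in place of 2-methoxyphenyl at that same place: 4-fluorophenyl in place of 2-methoxyphenyl on a double-bonded chain carbon bound to a double-bonded chain carbon.

All three measured steps bear on this change, as each is a swap at this place. For the measured compounds named here, the remaining one is a 1.4-fold higher number from compound 1 to compound 2 (0.15 log units; within the scatter), so none of the three exceeds the scatter, and no compound goes against this. Going by the values given here, no 4-fluorophenyl compound has been measured yet, and the expectation rests on these three steps alone. With 3-nitrophenyl, cyclopentyl and 2-methoxyphenyl all giving values within the scatter of one another, no step beyond the scatter is expected in this assay, in either direction. The expected step is a 1.3-fold lower number from compound 3 to compound 4 (0.10 log units; within the scatter). Compound 4 is estimated at 8000 nM, with an expected range from 4000 nM to 16000 nM.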

Compound 4, half-maximal inhibitory concentration: 8110 nM
Compound 4: the middle estimate sits 1.0-fold (0.01 log units) below what was measured; the measured number falls inside the stated range.
By their numbers in this assay, from the lowest: compounds 1, 4, 2 and 3 (each within the scatter of the next).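

In this assay, 4-fluorophenyl on a double-bonded chain carbon bound to a double-bonded chain carbon stays within the scatter of all three earlier groups: a 1.2-fold lower number from compound 3 to compound 4 (0.10 log units; within the scatter), a 1.1-fold lower number from compound 2 to compound 4 (0.05 log units; within the scatter) and a 1.3-fold higher number from compound 1 to compound 4 (0.11 log units; within the scatter). For the compounds shown here, the series now includes a fluorine-bearing ring, and the exchange of 2-methoxyphenyl, with 1 hydrogen-bond acceptor, for 4-fluorophenyl, with 0, gives no step beyond the scatter; across these four compounds, none of the groups at this place separates from another, and no compound goes against this. No measurement is available that would account for these numbers staying together.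

From the compounds shown here alone, it remains open whether a group of a different kind at this place, such as an amine, a carboxylic acid or a longer chain in place of the ring, would give a step beyond the scatter. The compounds shown also all share the same core, so they do not tell whether the same flat picture would hold with a change elsewhere, for instance if the hydroxyl group were replaced by a carbonyl.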